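A few compounds are considered here, and "the series" means these few. Any claim that something is new, unique, unknown or untested is made for them only; others in the source may bear on it.

Working notes on the series in an ADME assay on microsomes from liver (Homo sapiens) for metabolic stability; a higher number here means faster removal of the compound, a lower number slower removal.

Three compounds have numbers. Compound 1 `CCOc1cc([C@](O)(CCN(C)C)[C@@H](c2cc3cc(Br)ccc3nc2OC)c2cccc(OC)c2F)cc(OC)n1` gives 4.1 uL/min. Compound 2 `COc1cc([C@](O)(CCN(C)C)[C@@H](c2cc3cc(Br)ccc3nc2OC)c2cccc(OC)c2F)cc(OC(F)F)n1` gives 0.1 uL/min. Compound 3 `CCSc1cc([C@](O)(CCN(C)C)[C@H](c2ccccc2)c2cc3cc(Br)ccc3nc2OC)cc(SCC)n1` gives 2.3 uL/min. Compound 3 thus lies close to compound 1, with a gap within the scatter, and well away from compound 2, with a gap beyond it.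

Going by the values given here, the one single-point step with numbers on both sides is a 41-fold lower number from compound 1 to compound 2 (1.61 log units; beyond the scatter), difluoromethyl in place of ethyl on an oxygen on an aromatic ring.

Compound 4 `CCSc1cc([C@](O)(CCN(C)C)[C@@H](c2cc3cc(Br)ccc3nc2OC)c2cccc(OC)c2F)cc(SCC)n1` is not yet measured in this assay. It differs from compound 3 by 2-fluoro-3-methoxyphenyl in place of phenyl on a saturated chain carbon bound to an aromatic carbon and a saturated chain carbon. Among the compounds with values here, no measured pair isolates this change: compound 1 and compound 2 carry the 2-fluoro-3-methoxyphenyl group, compound 3 the phenyl, but they also differ in the groups on the pyridine ring, so the change from compound 3 to compound 4 cannot be read from them. The step from compound 1 to compound 2 concerns a different position and does not bear on it.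

Within the data shown here, with no step to lean on, the expectation for compound 4 is a number near that of compound 3, a step of a 1.1-fold higher number from compound 3 to compound 4 (0.04 log units; within the scatter) that stays within the scatter. Compound 4 is therefore estimated at 2.5 uL/min, with a range from 0.8 uL/min to 7 uL/min.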

Compound 4, intrinsic clearance in a liver preparation (reported as CLH), per the amount of preparation that the assay uses: 4.9 uL/min
Compound 4: the middle estimate sits 2.0-fold (0.29 log units) below what was measured, within the range that was stated.
By their numbers in this assay, from the lowest: compound 2; then compounds 3, 1 and 4 (each within the scatter of the next, the first and the last beyond it).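

In this assay, going by these compounds alone, the exchange of phenyl for 2-fluoro-3-methoxyphenyl on a saturated chain carbon bound to an aromatic carbon and a saturated chain carbon now has a reading of its own: the step is a 2.1-fold higher number from compound 3 to compound 4 (0.33 log units; beyond the scatter), modest in size and the only reading at this position. With 2-fluoro-3-methoxyphenyl held fixed, the step for the sulfur-bearing group of compound 4 against the oxygen-bearing group of compound 1 is a 1.2-fold higher number from compound 1 to compound 4 (0.08 log units; within the scatter), while the step against the difluoromethyl-bearing group of compound 2 is a 49-fold higher number from compound 2 to compound 4 (1.69 log units; beyond the scatter), so the large difference in this set goes with the difluoromethyl-bearing group rather than with the exchange of oxygen for sulfur. No measurement at hand explains either result.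

Still open, as far as these compounds go, is which part of the entering group goes with the modest step, a question that 2-fluorophenyl or 3-methoxyphenyl in the same place would address. Also open, from the compounds shown here alone, is whether difluoromethyl on sulfur would give a step of the size of a 41-fold lower number from compound 1 to compound 2 (1.61 log units; beyond the scatter).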